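Thiourea substituent in place of dichlorobenzyl on the shared core

The source may hold more compounds than are shown below. What is called first, only, known or untested is meant among the compounds shown, and "the series" means these compounds.

Measured compounds:
compound 1 `NC(=O)c1c(NC(=O)c2ccccc2Cl)sc2c1CCN(Cc1ccccc1F)C2`, 12900 nM
compound 2 `NC(=O)c1c(NC(=O)c2ccccc2Cl)sc2c1CCN(Cc1ccc(Cl)cc1Cl)C2`, 16300 nM

Compound 1 `NC(=O)c1c(NC(=O)c2ccccc2Cl)sc2c1CCN(Cc1ccccc1F)C2` and compound 2 `NC(=O)c1c(NC(=O)c2ccccc2Cl)sc2c1CCN(Cc1ccc(Cl)cc1Cl)C2` share one core and differ only in the group carried on the amine nitrogen in the ring. In a functional assay on MKN-74 cells (Homo sapiens) for antiproliferative activity, with a stated time of 24 h (a lower number here means a stronger inhibitor, a higher number a weaker inhibitor), compound 1 gives 12900 nM, and in this assay compound 2 gives 16300 nM. The step of a 1.3-fold higher number from compound 1 to compound 2 (0.10 log units; within the scatter) is the only one measured. On these two numbers compound 2 stands highest, with compound 1 as its nearest neighbour, but the two values lie within the scatter of each other, so no order between them can be claimed.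

Compound 3 `CSc1ccccc1NC(=S)N1CCc2c(sc(NC(=O)c3ccccc3Cl)c2C(N)=O)C1` is not yet measured. It differs from compound 2 as follows: a group of 11 heavy atoms (8 carbon, 1 nitrogen, 2 sulfur; one six-membered aromatic ring of carbon only) in place of a group of 9 heavy atoms (7 carbon, 2 chlorine; one six-membered aromatic ring of carbon only), on an amine nitrogen in a ring. Among the compounds with values here, no measured step covers a change of this kind; the one step that touches the same position, a 1.3-fold higher number from compound 1 to compound 2 (0.10 log units; within the scatter), changed the number by less than the scatter. On that basis compound 3 is expected to give a number close to that of compound 2, with the step of a 1.1-fold lower number from compound 2 to compound 3 (0.04 log units; within the scatter) not expected to exceed the scatter. The estimate for compound 3 in this assay is 15000 nM, within a range of 5000 nM to 45000 nM.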

Compound 3, half-maximal inhibitory concentration: 13800 nM
Compound 3: the middle estimate sits 1.1-fold (0.04 log units) above what was measured; the measured number falls inside the stated range.
By their numbers in this assay, from the lowest: compounds 1, 3 and 2 (each within the scatter of the next).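

Until now, this position had been seen carrying only halogenated benzyl groups. Compound 3 puts the thiourea substituent on the amine nitrogen in a ring, a group with 1 hydrogen-bond donor, 2 hydrogen-bond acceptors and 1 double bond outside aromatic rings, where the benzyl groups have neither donor nor acceptor. Even so, this assay shows a 1.2-fold lower number from compound 2 to compound 3 (0.07 log units; within the scatter) and a 1.1-fold higher number from compound 1 to compound 3 (0.03 log units; within the scatter), so all three groups give numbers that cannot be told apart, and a change of this kind at this position leaves the antiproliferative read-out within the scatter, with no evidence available to explain why.

What the compounds shown leave open is whether any group on this nitrogen can move the number beyond the scatter, since a urea with oxygen in place of the thiourea sulfur, an acetyl group, a longer alkyl chain or a chain ending in a carboxylic acid or an amine do not appear among them. They also leave open whether the sulfur-bearing ring of the thiourea substituent contributes anything, as a plain phenyl thiourea is not among them either.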